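Shifting Methyl Groups in a Pair of Growth Inhibitors

The source may hold more compounds than are shown below. What is called first, only, known or untested is meant among the compounds shown, and "the series" means these compounds.

Compound 1 `COc1cc(Nc2ncnc3c(NC(=O)Nc4ccc(C)cc4C)cccc23)cc(OC)c1` gives 1290 nM in a functional assay on RT-112 cells (Homo sapiens) for antiproliferative activity, read by MTT assay, with a stated time of 72 h; a lower number here means a stronger inhibitor of growth, a higher number a weaker inhibitor of growth 
Compound 2 `COc1cc(Nc2ncnc3c(NC(=O)Nc4cccc(C)c4C)cccc23)cc(OC)c1` gives 5910 nM in this assay 

Compound 2 holds the higher of the two numbers, so it is the weaker growth inhibitor of this pair. The measured step is a 4.6-fold higher number from compound 1 to compound 2 (0.66 log units; beyond the scatter) and it came from putting 2,3-dimethylphenyl in place of 2,4-dimethylphenyl on an amide-type nitrogen.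

Compound 3 `COc1cc(Nc2ncnc3c(NC(=O)Nc4cc(C)cc(C)c4)cccc23)cc(OC)c1` changes the same place once more: 3,5-dimethylphenyl in place of 2,3-dimethylphenyl on an amide-type nitrogen and the rest of the structure stays the same. Going by the values given here, that single measured step is the only guide here. It shows that rearranging the methyl groups on this ring can move the number beyond the scatter, so a modest step is a reasonable expectation. Among the compounds with values here, no measured compound carries 3,5-dimethylphenyl, so the direction is uncertain. Compound 2 at 5910 nM sits at the top of the two values, which makes a move to a lower number the better guess. The expected change is a 2.4-fold lower number from compound 2 to compound 3 (0.37 log units; beyond the scatter) in this assay for this estimate. Compound 3 is expected at 2500 nM within a range from 700 nM to 9000 nM as a rough estimate.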

Compound 3, concentration for 50% growth inhibition: 10100 nM
For compound 3 the middle estimate is 4.0-fold (0.61 log units) below the measured one, and the stated range ends below it.
By their numbers in this assay, from the lowest: compound 1; then compounds 2 and 3 (each within the scatter of the next).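

In this assay the step of a 1.7-fold higher number from compound 2 to compound 3 (0.23 log units; within the scatter) stays within the scatter, so on this amide-type nitrogen 3,5-dimethylphenyl and 2,3-dimethylphenyl cannot be told apart. The step of a 7.8-fold higher number from compound 1 to compound 3 (0.89 log units; beyond the scatter) lies beyond the scatter, so compound 1, with 2,4-dimethylphenyl, now stands apart from two other arrangements of the same atoms instead of only one. Among these three compounds, rearranging the two methyl groups therefore gives no graded series: compound 1 is the strongest growth inhibitor, while compound 2 and compound 3 sit together at weaker values.

Nothing shown here explains why the 2,4-dimethylphenyl compound stands apart from the other two. Still open, as far as these compounds go, are how 3,4-dimethylphenyl or 2,5-dimethylphenyl would compare, and whether a plain phenyl, a single methyl group or a chlorine or methoxy group on this ring would give a number closer to compound 1 or to the other two.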